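This account rests on a few compounds, and the source may have more. Where it says the series, first, only, none or still open, it means among the compounds named here.

Measured so far in a functional assay on HeLa cells (Homo sapiens) for antiproliferative activity, read by MTT assay, with a stated time of 48 h; on this read-out lower numbers stand for stronger inhibition and higher numbers for weaker inhibition:
Compound 1 `CCN(CC)CCCCn1c(N)c(-c2nc3ccccc3n2C)c2nc(C#N)c(C#N)nc21`: 1610 nM
Compound 2 `CN(C)CCn1c(N)c(-c2nc3cc(Cl)ccc3[nH]2)c2nc(C#N)c(C#N)nc21`: > 50000 nM, a limit of the assay and not a number
Compound 3 `CCN(CC)CCCn1c(N)c(-c2nc3cc(Cl)ccc3[nH]2)c2nc(C#N)c(C#N)nc21`: 24400 nM

Of the two exact numbers, compound 3 at 24400 nM holds the higher one, and compound 1 lies lower by a margin beyond the scatter. Compound 4 `CCN(CC)CCCCn1c(N)c(-c2nc3cc(Cl)ccc3[nH]2)c2nc(C#N)c(C#N)nc21` has not yet been measured. It differs from compound 3 in one place: (diethylamino)methyl in place of diethylamino on a saturated chain carbon, three bonds along the chain from an aromatic nitrogen. Read one bond further out, this is 3-(diethylamino)propyl to 4-(diethylamino)butyl.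

Going by the values given here, only one measured step bears directly on this change, an at least 2.0-fold lower number from compound 2 to compound 3 (0.31 log units; beyond the scatter). On these data alone, it points towards a lower number, although its full size stays open. Among the compounds with values here, no single-place step links compound 1 with compound 3, so the lower number of compound 1 offers only weak support. A moderate fall beyond the scatter is therefore expected in this assay. The expected change is estimated as a 3.1-fold lower number from compound 3 to compound 4 (0.48 log units; beyond the scatter). Compound 4 is expected at an estimated 8000 nM, with a range of 2000 nM to 26000 nM.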

Compound 4, half-maximal inhibitory concentration: 3640 nM
Compound 4: the middle estimate sits 2.2-fold (0.34 log units) above what was measured, and the stated range covers the measured number.
By their numbers in this assay, from the lowest: compound 1; then compound 4; then compound 3. At a limit, above all of these: compound 2.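

In this assay, the change from 3-(diethylamino)propyl to 4-(diethylamino)butyl gives a 6.7-fold lower number from compound 3 to compound 4 (0.83 log units; beyond the scatter), the first step along this chain with an exact number at both ends. With the 4-(diethylamino)butyl chain held constant, 5-chloro-1H-benzimidazol-2-yl in place of 1-methyl-1H-benzimidazol-2-yl gives a 2.3-fold higher number from compound 1 to compound 4 (0.35 log units; beyond the scatter), the first single-place link between compound 1 and the chlorinated compounds. Compound 2 stands at a limit of the assay and not a number, so an at least 13-fold lower number from compound 2 to compound 4 (1.13 log units; beyond the scatter) fixes only the least size of that step: the limit of > 50000 nM in this assay, at which 1 of the 4 values shown sits.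

The compounds shown do not tell whether a 5-(diethylamino)pentyl chain would lower the number further. They also leave open how a 4-(dimethylamino)butyl chain, or a piperidine or morpholine at the end of the butyl chain, would compare with the diethylamino group.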